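This account rests on a few compounds, and the source may have more. Where it says the series, first, only, none or still open, it means among the compounds named here.

Compound 1 `C/C(=N/NC(=O)Nc1nc(-c2ccc(F)cc2)cc(-c2ccc([N+](=O)[O-])cc2)n1)c1ccc(C)cc1`: 300 mg/kg
Compound 2 `C/C(=N/NC(=O)Nc1nc(-c2ccc(C)cc2)cc(-c2ccc(F)cc2)n1)c1ccc([N+](=O)[O-])cc1`: 300 mg/kg
Compound 3 `C/C(=N/NC(=O)Nc1nc(-c2ccc(Cl)cc2)cc(-c2ccc([N+](=O)[O-])cc2)n1)c1ccc(C)cc1`: 300 mg/kg

All three were tested in a functional assay on the whole organism (strain Albino) with Mus musculus as the target, with a stated time of 4 h; on this read-out higher numbers stand for an effect only at larger amounts of compound and lower numbers for an effect already at smaller amounts. Compound 1 and compound 2 are built from the same atoms joined differently; the difference between the two cores is not broken down here. Compound 3 arises from compound 1 by a single change, (chloro in place of fluoro on an aromatic carbon), and this change made no change at the digits printed from compound 1 to compound 3 (within the scatter). Compound 2 stands level with compound 1 and compound 3 at the digits given. Compound 4 `C/C(=N/NC(=O)Nc1nc(-c2ccc(C)cc2)cc(-c2ccc(Cl)cc2)n1)c1ccc([N+](=O)[O-])cc1` has not yet been measured; it arises from compound 2 by the same change, (chloro in place of fluoro on an aromatic carbon). Among the measured compounds shown here, since the one earlier example of this change gave no change at the digits printed from compound 1 to compound 3 (within the scatter), compound 4 is expected to show a step of no change at the digits printed from compound 2 to compound 4 (within the scatter) in this assay. The estimate for compound 4 is 300 mg/kg, expected to fall between 150 mg/kg and 600 mg/kg.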

Compound 4, dose for half-maximal effect: 300 mg/kg
The estimate for compound 4 equals the measured number at the digits printed; low and high end bracket the measured number.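

Putting chloro in place of fluoro on the second core gave no change at the digits printed from compound 2 to compound 4 (within the scatter) in this assay, and the two cores agree on this change: the same change on two cores in this assay, no change at the digits printed (within the scatter) from compound 1 to compound 3 and no change at the digits printed (within the scatter) from compound 2 to compound 4, 1.0-fold (0.00 log units) apart, within the scatter of two such steps. On these two cores, then, the change carries over from one to the other with no visible effect on the dose. This does not show why the dose stayed the same, and two pairs of compounds, all at one shared value, cannot show that the same would hold on a further core.

The compounds shown leave open what other groups would do on that ring, such as an amine or a carboxylic acid. They also leave open whether an amine in place of the nitro group would shift the dose.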